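The compounds below may be only part of what the source reports. "The series", "measured", "known", "first", "only" and "open" are said of these compounds alone.

Measured compounds:
- Compound 1, `NS(=O)(=O)c1ccc(Nc2nc(N/N=C/c3ccc(C(F)(F)F)cc3)nc(Nc3ccccc3)n2)cc1`: 64800 nM
- Compound 2, `Cc1nn(-c2ccccc2)cc1/C=N/Nc1nc(Nc2ccccc2)nc(Nc2ccc(S(N)(=O)=O)cc2)n1`: 7590 nM

These values come from a functional assay on MCF7 cells (Homo sapiens) for inhibition, read by sulforhodamine B assay, with a stated time of 48 h; a lower number here means that less compound is tolerated, a higher number that more compound is tolerated. Of the compounds measured, compound 2 gives the lowest number, and the nearest is compound 1, an 8.5-fold lower number from compound 1 to compound 2 (0.93 log units; beyond the scatter) apart.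

Compound 3, `NS(=O)(=O)c1ccc(Nc2nc(N/N=C/c3ccccn3)nc(Nc3ccccc3)n2)cc1`, has not yet been measured in this assay. It differs from compound 2 in one place: pyridin-2-yl in place of 3-methyl-1-phenyl-1H-pyrazol-4-yl on a carbon with a double bond to nitrogen.

Within the data shown here, only one measured step touches the same position, the one from compound 1 to compound 2, where replacing the 4-(trifluoromethyl)phenyl by the 3-methyl-1-phenyl-1H-pyrazol-4-yl gave an 8.5-fold lower number from compound 1 to compound 2 (0.93 log units; beyond the scatter). That shows this position matters, but neither measured group resembles the pyridin-2-yl, so the direction for compound 3 is uncertain. Among the measured compounds shown here, since the only comparison, an 8.5-fold lower number from compound 1 to compound 2 (0.93 log units; beyond the scatter), was a modest move between two differing groups, compound 3 is expected to land somewhere in that span, as a 2.6-fold higher number from compound 2 to compound 3 (0.42 log units; beyond the scatter). The estimate for compound 3 is 20000 nM, within 5000 nM to 80000 nM.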

Compound 3, concentration lethal to 50% of the cells: 6800 nM
The estimate for compound 3 lay 2.9-fold (0.47 log units) above the measured number; the measured number falls inside the stated range.
By their numbers in this assay, from the lowest: compounds 3 and 2 (each within the scatter of the next); then compound 1.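

In this assay the pyridin-2-yl, with one ring where the 3-methyl-1-phenyl-1H-pyrazol-4-yl has two, gives a 1.1-fold lower number from compound 2 to compound 3 (0.05 log units; within the scatter) and so matches the larger group on this carbon. Set against the 4-(trifluoromethyl)phenyl, the same change gives a 9.5-fold lower number from compound 1 to compound 3 (0.98 log units; beyond the scatter) and thus shows that the second ring of the pyrazole group is not needed to reach the lower level; of the three groups, only the 4-(trifluoromethyl)phenyl stands apart. No measurement at hand explains why these groups compare as they do.

As far as these compounds go, whether the ring nitrogen of the pyridin-2-yl matters remains open, and an unsubstituted phenyl on this carbon would help to test that. From the compounds shown here alone, it is also open whether this position needs an aromatic ring at all, which a simple ethyl chain or an amine-bearing chain could probe.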